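The source may report more compounds than this note shows. Statements on the series, on what has been measured and on what is new or still open speak of the compounds shown alone.

Compound 1 `COc1ccc(Cc2cc(OC3CCCCC3C)c(C(C)C)c(=O)[nH]2)cc1` is the starting point of this account. In an ADME assay on MT4 cells (Homo sapiens) for cytotoxicity, read by XTT assay, with a stated time of 3 days (a lower number here means that less compound is tolerated, a higher number that more compound is tolerated), compound 1 gives 74500 nM, the highest of the two numbers shown, with compound 2 `CC(C)c1c(OC2CCCCC2C)cc(Cc2ccc(F)cc2)[nH]c1=O` nearest at 64600 nM. Among the measured compounds shown here, the one measured step, a 1.2-fold lower number from compound 1 to compound 2 (0.06 log units; within the scatter), concerns the substituent on the aromatic ring of the side chain and stays within the scatter. Compound 3 `CC1CCCCC1Oc1cc(CCc2ccccc2)[nH]c(=O)c1I` reaches only a limit in this assay, > 300000 nM, and so contributes no number. Compound 4 `CC(C)c1c(OC2CCCCC2C)cc(CCc2ccccc2)[nH]c1=O` differs from compound 1 by benzyl in place of 4-methoxyphenyl on a saturated chain carbon bound to an aromatic carbon. For the measured compounds named here, the only measured step that bears on this part of the molecule is the change from compound 1 to compound 2, which was within the scatter, so the change to compound 4 is expected to move this assay little beyond the scatter, if at all, in either direction. Compound 4 is therefore expected to give about 90000 nM in this assay, within 40000 nM to 250000 nM, meaning a step of a 1.2-fold higher number from compound 1 to compound 4 (0.08 log units; within the scatter).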

Compound 4, half-maximal cytotoxic concentration: 201000 nM
Estimate against measurement, compound 4: 2.2-fold (0.35 log units) below; the range from low to high includes it.
By their numbers in this assay, from the lowest: compounds 2 and 1 (each within the scatter of the next); then compound 4. At a limit, above all of these: compound 3.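

In this assay, among the compounds shown here, the change from 4-methoxybenzyl to phenethyl gives the first steps at this position that lie beyond the scatter, though both are modest: a 2.7-fold higher number from compound 1 to compound 4 (0.43 log units; beyond the scatter), and a 3.1-fold higher number from compound 2 to compound 4 (0.49 log units; beyond the scatter). The swap of fluoro for methoxy on the ring had not separated compound 1 and compound 2, so this position responds to the side chain as a whole more than that swap alone showed. The comparison at the isopropyl position can be read only as a floor, an at least 1.4-fold lower number from compound 3 to compound 4 (0.17 log units; that floor lies within the scatter), since compound 3 stands at a limit: the limit of > 300000 nM in this assay, at which 1 of the 4 values shown sits.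

The step to compound 4 alters the chain length and removes the ring substituent at once, and the compounds shown do not separate the two. A phenethyl carrying a methoxy group on its ring, or a longer phenylpropyl chain, would bear on this.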